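The source may hold more compounds than are shown below. What is called first, only, known or untested is meant among the compounds shown, and "the series" means these compounds.

Compound 1 `COc1cncc(C2=CC3CC(C2)CN(C)C3)c1` gives 15% in an in vitro functional assay on SH-EP1 cells for agonist activity at Neuronal acetylcholine receptor; alpha4/beta2 (Homo sapiens), read by FLIPR and calcium flux (on this read-out lower numbers stand for smaller maximal responses and higher numbers for larger maximal responses), the lowest of the three numbers measured. Compound 3 `COc1cncc(C2=CC3CNCC(C2)C3)c1` gives 100% in this assay, and compound 2 `C1=C(c2cccnc2)C[C@H]2CNC[C@@H]1C2` gives 129%. Among the measured compounds shown here, the single measured step, a number 85 percentage points higher from compound 1 to compound 3 (beyond the scatter), concerns the amine nitrogen in the ring and not the ether. Compound 4 `CC(C)Oc1cncc(C2=CC3CC(C2)CN(C)C3)c1` differs from compound 1 by isopropyl in place of methyl on an oxygen on an aromatic ring. For the measured compounds named here, no measured step touches the ether group, so nothing among the three compounds sets the size or direction of this change, while compound 4 keeps the methyl on the amine nitrogen that compound 1 carries. The step expected is therefore a number 5 percentage points higher from compound 1 to compound 4 (within the scatter), within the scatter. Compound 4 is expected to give 20%, between 5% and 45%.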

Compound 4, largest response reached (reported as percent of maximum), in percent of the reference or control that the assay uses: 3.3%
Compound 4: the middle estimate sits 16.7 percentage points above what was measured, and the stated range ends above it.
By their numbers in this assay, from the lowest: compound 4; then compound 1; then compound 3; then compound 2.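

In this assay, the ether position proves able to move the response: methoxy to isopropoxy gives a number 11.7 percentage points lower from compound 1 to compound 4 (beyond the scatter). This step is downward and smaller than a number 85 percentage points higher from compound 1 to compound 3 (beyond the scatter), the change at the amine nitrogen. Nothing available explains the drop at the ether.

From the compounds shown here alone, whether ethoxy would give a response between those of the methoxy and isopropoxy compounds remains open. So does whether isopropoxy would also lower the response with hydrogen on the amine nitrogen, as in compound 3.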